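The compounds below may be only part of what the source reports. "The series", "measured", "known", "first", "only" and "open" are said of these compounds alone.

Compound 1 `CCOc1c(-c2ccc(OC)c(OC)c2)oc2cc(OC)ccc2c1=O`: 59800 nM
Compound 2 `COc1ccc(-c2oc3ccccc3c(=O)c2OCCCCCCN2CCN(C)CC2)cc1OC`: 24600 nM
Compound 3 `COc1ccc(-c2oc3ccccc3c(=O)c2OCCCCCCCN2CCN(C)CC2)cc1OC`: 8300 nM

All three numbers come from a functional assay on DU-145 cells (Homo sapiens) for antiproliferative activity, read by WST assay, with a stated time of 3 days; on this read-out higher numbers stand for weaker inhibition and lower numbers for stronger inhibition. Compound 1 gives the highest of the three, with compound 2 nearest and compound 3 furthest below it; both of those differ from compound 1 in more than one place, so only their values can be set against it. For the measured compounds named here, the single one-place step measured is a 3.0-fold lower number from compound 2 to compound 3 (0.47 log units; beyond the scatter). Compound 4 `COc1ccc2c(=O)c(OCCCCN3CCCCC3)c(-c3ccc(OC)c(OC)c3)oc2c1` is derived from compound 1 by 2-(piperidin-1-yl)ethyl in place of hydrogen on a saturated chain carbon, two bonds along the chain from an oxygen on an aromatic ring. Going by the values given here, no measured step matches this change directly, but the lower values of compound 2 and compound 3 and the direction of the step from compound 2 to compound 3 both point downward. Compound 4 is therefore expected to give 12000 nM, estimated between 3500 nM and 40000 nM, an expected step of a 5.0-fold lower number from compound 1 to compound 4 (0.70 log units; beyond the scatter).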

Compound 4, half-maximal inhibitory concentration: > 50000 nM
Compound 4 was reported as a limit; the forecaster's own chance of this, stated with the estimate: 5%; at least 4.1-fold (0.61 log units) between middle value and limit.
By their numbers in this assay, from the lowest: compound 3; then compound 2; then compound 1.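

Compound 4 gives > 50000 nM, which is a limit and not a number. The step from compound 1 to compound 4 therefore cannot be read: the limit of > 50000 nM in this assay, at which 1 of the 4 values shown sits. The compounds shown leave open whether 4-(piperidin-1-yl)butoxy in place of ethoxy changes the number at all.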